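A few compounds are considered here, and "the series" means these few. Any claim that something is new, unique, unknown or untested is made for them only; others in the source may bear on it.

Measured compounds:

Compound 1, `C/C(=C\c1cc(-c2ccc(S(C)(=O)=O)cc2)cs1)C(N)=O`: in an ADME assay on NIH3T3 cells (Mus musculus) for cytotoxicity, read by CCK-8 assay, with a stated time of 24 h (on this read-out lower numbers stand for stronger inhibition and higher numbers for weaker inhibition), compound 1 gives > 50000 nM, which is a limit of the assay.

Compound 2, `COc1ccc(-c2csc(/C=C(\C)C(N)=O)c2)cc1`: in this assay compound 2 gives > 50000 nM, also a limit of the assay.

Compound 2 stands where both measured compounds stand: at the limit of > 50000 nM in this assay, at which 2 of the 2 values shown sit. Among the measured compounds shown here, its single measurement is a limit, so no number places it within the scale.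

Compound 3, `C=Cc1ccc(-c2csc(/C=C(\C)C(N)=O)c2)cc1`, differs from compound 2 in one place: vinyl in place of methoxy on an aromatic carbon. The change sits on an aromatic carbon of a six-membered aromatic ring of carbon only, para to a large group.

For the measured compounds named here, the only measured step touching this ring position is a step that the two limits leave unreadable from compound 1 to compound 2, and it is unreadable in size. Going by the values given here, no measured step therefore tells how a vinyl group in that position shifts the read-out, and nothing among the measured compounds points away from the limit. Compound 3 is accordingly expected to remain near the limit as well, with a step that the limit leaves unreadable from compound 2 to compound 3 that is not expected to exceed the scatter.

The estimate for compound 3 in this assay is 80000 nM, with a range from 30000 nM to 300000 nM.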

Compound 3, half-maximal inhibitory concentration: > 50000 nM
Compound 3 gave a limit, no number; the forecaster's own chance of this, stated with the estimate: 85%; the middle value does not contradict the limit.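

In this assay compound 3 gives > 50000 nM, which is a limit of the assay. Among the compounds shown here, no step among compound 1, compound 2 and compound 3 can therefore be read, and the three share one position: the limit of > 50000 nM in this assay, at which 3 of the 3 values shown sit. The compounds shown leave open whether the methylsulfonyl, methoxy and vinyl groups differ at all in this read-out.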